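Compound 1 to compound 4: a 3,4-dihydroxyphenyl swap

This account rests on a few compounds, and the source may have more. Where it says the series, first, only, none or still open, it means among the compounds named here.

Compound 1 `COc1ccc(Oc2ccc(C(C)C)cc2-c2ccsc2S(=O)(=O)NCCNC(=S)Nc2ccc([N+](=O)[O-])cc2)cc1OC` gives 11400 nM in an ADME assay on HEK-293T cells (Homo sapiens) for cytotoxicity, read by CCK-8 assay, with a stated time of 48 h (on this read-out higher numbers stand for weaker inhibition and lower numbers for stronger inhibition), and compound 2 `COc1ccc(Oc2ccc(C(C)C)cc2-c2ccsc2S(=O)(=O)NCCNC(=O)Nc2cc(Cl)cc(Cl)c2)cc1OC` gives 11900 nM in the same read-out, while compound 3 `O=[N+]([O-])c1cccc(NC(=S)NCCNS(=O)(=O)c2ccc(-c3ccccc3OCc3ccccc3)s2)c1` gives 18300 nM there. Both of these lie within the scatter of compound 1, so it holds no distinct place among the three.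

Compound 4 `CC(C)c1ccc(Oc2ccc(O)c(O)c2)c(-c2ccsc2S(=O)(=O)NCCNC(=S)Nc2ccc([N+](=O)[O-])cc2)c1` departs from compound 1 by 3,4-dihydroxyphenyl in place of 3,4-dimethoxyphenyl on an oxygen on an aromatic ring with 3,4-dihydroxyphenyl in place of 3,4-dimethoxyphenyl on an oxygen on an aromatic ring.

Within the data shown here, the one measured step is a 1.0-fold higher number from compound 1 to compound 2 (0.02 log units; within the scatter) and lies within the scatter, but it replaces the group on an amine nitrogen and leaves the 3,4-dimethoxyphenyl untouched. It bears on the present change only indirectly, showing that the number did not move beyond the scatter when another part of compound 1 was replaced. Among the measured compounds shown here, no measured compound carries 3,4-dihydroxyphenyl, so the data give no direct size for this change.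

No step beyond the scatter is therefore expected in this assay and the expected step of a 1.1-fold lower number from compound 1 to compound 4 (0.06 log units; within the scatter) has no firm direction. Compound 4 is estimated at 10000 nM as a middle value, with an expected range from 4000 nM to 22000 nM around it.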

Compound 4, half-maximal inhibitory concentration: 16300 nM
Compound 4: the middle estimate sits 1.6-fold (0.21 log units) below what was measured; measured number inside the range.
By their numbers in this assay, from the lowest: compounds 1, 2, 4 and 3 (each within the scatter of the next).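

Among these compounds, replacing 3,4-dimethoxyphenyl with 3,4-dihydroxyphenyl on an oxygen on an aromatic ring gives a 1.4-fold higher number from compound 1 to compound 4 (0.16 log units; within the scatter) in this assay, the first direct reading for this place, and it lies within the scatter. The earlier single step, a 1.0-fold higher number from compound 1 to compound 2 (0.02 log units; within the scatter), concerned only the group on an amine nitrogen, so the series now has two separate places at which one replacement stays within the scatter in this read-out. No supporting measurement bears on this result.

Still open, as far as these compounds go, is whether a carboxylic acid or an amine on the aromatic ring in place of the two hydroxy groups, or a longer chain on the oxygens in place of the methyl groups of the 3,4-dimethoxyphenyl, would give a step beyond the scatter. From the compounds shown here alone, it is also open whether 3,4-dihydroxyphenyl in place of 3,4-dimethoxyphenyl would read the same in compound 2, which carries a different group on the amine nitrogen.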